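The source may hold more compounds than are shown below. What is called first, only, known or untested is meant among the compounds shown, and "the series" means these compounds.

Measured compounds:
Compound 1 `O=c1[nH]/c(=N\OCCCc2cccc(I)c2)ccn1[C@@H]1O[C@H](COP(=O)(O)OP(=O)(O)OP(=O)(O)O)[C@@H](O)[C@H]1O` gives 299 nM in a functional assay on 1321-N1 cells for agonist activity at P2Y purinoceptor 6 (Homo sapiens), read by scintillation counting and inositol phosphate accumulation; a lower number here means that less compound is needed, a higher number that more compound is needed for the effect.
Compound 2 `C#CCCCO/N=c1/ccn([C@@H]2O[C@H](COP(=O)(O)OP(=O)(O)OP(=O)(O)O)[C@@H](O)[C@H]2O)c(=O)[nH]1` gives 3000 nM in this assay.

Going by the values given here, compound 2 stands highest of the two measured numbers in this assay; its nearest neighbour is compound 1, and the only measured step, a 10-fold higher number from compound 1 to compound 2 (1.00 log units; beyond the scatter), separates them. Compound 3 `O=c1[nH]/c(=N\OCCCc2ccc3ccccc3c2)ccn1[C@@H]1O[C@H](COP(=O)(O)OP(=O)(O)OP(=O)(O)O)[C@@H](O)[C@H]1O` has not yet been measured. It differs from compound 2 as follows: naphthalen-2-yl in place of ethynyl on a saturated chain carbon, three bonds along the chain from an oxygen on an unsaturated carbon. Among the compounds with values here, the one step that bears on this change is a 10-fold higher number from compound 1 to compound 2 (1.00 log units; beyond the scatter), which shows that replacing an aromatic ring with ethynyl at this position raised the number well beyond the scatter. Compound 3 restores an aromatic group at the same position, so the step is expected to run back in the opposite direction, roughly undoing that loss, and a 7.5-fold lower number from compound 2 to compound 3 (0.88 log units; beyond the scatter) is the estimated size. Compound 3 is therefore expected to give about 400 nM in this assay, with a likely range from 100 nM to 1600 nM.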

Compound 3, half-maximal effective concentration: 90 nM
Beside the measured number, compound 3's estimate is 4.4-fold (0.65 log units) above it; measured number below the stated range.
By their numbers in this assay, from the lowest: compound 3; then compound 1; then compound 2.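

In this assay the change from ethynyl to naphthalen-2-yl gives a 33-fold lower number from compound 2 to compound 3 (1.52 log units; beyond the scatter) and this is larger in size than the opposite step of a 10-fold higher number from compound 1 to compound 2 (1.00 log units; beyond the scatter) alone. The position also separates one aromatic group from another: naphthalen-2-yl in place of 3-iodophenyl gives a 3.3-fold lower number from compound 1 to compound 3 (0.52 log units; beyond the scatter) and so the earlier contrast between an aromatic group and ethynyl was only part of the picture. Nothing measured here accounts for this order of the three compounds.

What the three compounds leave open is whether the gain comes with the second aromatic ring itself or with the way the group is attached, which naphthalen-1-yl or plain phenyl could test. Going by these compounds, it is also open how a pyridine ring or a longer chain would fare at this position.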